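This account rests on a few compounds, and the source may have more. Where it says the series, first, only, none or still open, it means among the compounds named here.

Measured in an assay for inhibition of histone-lysine N-methyltransferase, H3 lysine-79 specific (Homo sapiens), read by scintillation counting, with stated times of 15 min and 60 min, tested at 50 uM, in the presence of a further agent that is not named here; on this read-out higher numbers stand for a stronger effect at the one concentration tested and lower numbers for a weaker effect:
compound 1 `C(=C/c1nn2c(-c3ccncc3)nnc2s1)\c1ccco1` gives 67%
compound 2 `Fc1cccc(-c2nnc3sc(CCc4ccccc4)nn23)c1` gives 43%
compound 3 `Cc1occc1-c1nnc2sc(CCc3ccccc3)nn12` gives 11%

Compound 1 stands highest of the three; compound 2 sits next, beyond the scatter, and compound 3 furthest, also beyond the scatter. The step of a number 32 percentage points lower from compound 2 to compound 3 (beyond the scatter) shows that exchanging the aryl group on the aromatic carbon of the shared core moves the read-out by a large amount. Compound 4 `Cc1cccc(-c2nnc3sc(/C=C/c4ccco4)nn23)c1` keeps the rest of compound 1 and differs only there: 3-methylphenyl in place of pyridin-4-yl on an aromatic carbon. Going by the values given here, compound 2, carrying 3-fluorophenyl on that aromatic carbon, gives 43%, but its other substituent differs from that of compound 1, so no measured pair covers this exact exchange. A moderate loss is expected, a number 15 percentage points lower from compound 1 to compound 4 (beyond the scatter). Compound 4 is therefore estimated at 52%, ranging from 28% to 76%.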

Compound 4, a percentage reported as inhibition, at one concentration (the size of the read-out at that concentration, not a potency): 69%
Compound 4: middle estimate off by 17 percentage points, on the low side; the range from low to high includes it.
By their numbers in this assay, from the lowest: compound 3; then compound 2; then compounds 1 and 4 (each within the scatter of the next).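

At this aromatic carbon of the shared core, in this assay, 3-methylphenyl in place of pyridin-4-yl leaves the read-out level (a number 2 percentage points higher from compound 1 to compound 4 (within the scatter)), so the ring nitrogen and its hydrogen-bond acceptor are not required for it alongside the substituent of compound 1. This position therefore does not respond to every aryl exchange, although the earlier step there was large (a number 32 percentage points lower from compound 2 to compound 3 (beyond the scatter)). No supporting measurement explains this result.

Open, as far as these compounds go, is whether a basic amine or a carboxylic acid on this carbon would hold the read-out. Also open, from the compounds shown here alone, is whether 3-methylphenyl and pyridin-4-yl would remain level with the other substituent of compound 2.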